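Removing One Hydroxy From a Sugar Ester

The source may hold more compounds than are shown below. What is called first, only, known or untested is meant among the compounds shown, and "the series" means these compounds.

The measured compounds, all in a toxicity assay on MRC5 cells (Homo sapiens) for antiproliferative activity, read by MTT assay, with a stated time of 72 h; on this read-out lower numbers stand for stronger inhibition and higher numbers for weaker inhibition:
compound 1, `COC(=O)CCSSc1ccccc1/C=N/NC(=O)c1ccccc1`, gives 12000 nM;
compound 2, `O=C(CCSSc1ccccc1/C=N/NC(=O)c1ccccc1)N[C@H]1C(O)O[C@H](CO)[C@@H](O)[C@@H]1O`, gives 33000 nM;
compound 3, `O=C(CCSSc1ccccc1/C=N/NC(=O)c1ccccc1)OC[C@H]1OC(O)[C@H](O)[C@@H](O)[C@@H]1O`, gives 26000 nM.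

Compound 3 sits close to compound 2: the two numbers lie within the scatter of each other, so no order between them can be read. Compound 1 lies apart, and the step of a 2.2-fold higher number from compound 1 to compound 3 (0.34 log units; beyond the scatter) is beyond the scatter though modest. That single step, 3,4,5,6-tetrahydroxyoxan-2-yl in place of hydrogen on a saturated chain carbon bound to an oxygen next to a carbonyl group, is the only one available and it concerns the whole sugar, not one of its hydroxy groups.

Compound 4, `O=C(CCSSc1ccccc1/C=N/NC(=O)c1ccccc1)OC[C@H]1OC(O)C[C@@H](O)[C@@H]1O`, differs from compound 3 by hydrogen in place of hydroxy on a saturated ring carbon. Since adding the whole sugar moved this assay only modestly, the loss of one hydroxy from it is expected to move it less, with no step beyond the scatter. For compound 4 the expected value in this assay is 24000 nM, within 11000 nM to 55000 nM, an expected step of a 1.1-fold lower number from compound 3 to compound 4 (0.03 log units; within the scatter).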

Compound 4, half-maximal inhibitory concentration: 29000 nM
Compound 4: the middle estimate sits 1.2-fold (0.08 log units) below what was measured; the measured number falls inside the stated range.
By their numbers in this assay, from the lowest: compound 1; then compounds 3, 4 and 2 (each within the scatter of the next).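

In this assay, hydrogen can stand in place of hydroxy on this saturated ring carbon, two ring bonds from the ring oxygen, with no readable change: the result is a 1.1-fold higher number from compound 3 to compound 4 (0.05 log units; within the scatter). The sugar group without this hydroxy still keeps its distance from the plain ester, with a 2.4-fold higher number from compound 1 to compound 4 (0.38 log units; beyond the scatter), so that step, though modest, does not need this hydroxy to appear. Nothing measured here speaks to what lies behind either result.

The compounds shown leave open whether an amine or a methoxy group on this same ring carbon would also read like hydroxy and hydrogen. They also leave open whether the hydroxy groups on the neighbouring ring atoms could give way to hydrogen in the same manner.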